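The source may report more compounds than this note shows. Statements on the series, on what has been measured and on what is new or still open speak of the compounds shown alone.

Within the data shown here, in a functional assay on HUVEC cells (Homo sapiens) for antiproliferative activity, read by MTT assay, with a stated time of 24 h (on this read-out higher numbers stand for weaker inhibition and lower numbers for stronger inhibition), compound 1 `C=CCc1cc(-c2cccc(C(F)(F)F)c2)ccc1O` gives 76000 nM, the only actual number so far. Compound 2 `C=CCc1cc(-c2ccc(OC)cc2)ccc1O`, which also carries a methoxy group, reads > 100000 nM, and this is a limit of the assay, not a number. Compound 3 `C=CCc1cc(-c2cccc(OC)c2)ccc1O` differs from compound 1 in one place: methoxy in place of trifluoromethyl on an aromatic carbon. Among the measured compounds shown here, no measured pair shows this change directly in this assay. The expected step, a 1.3-fold higher number from compound 1 to compound 3 (0.12 log units; within the scatter), leans towards weaker inhibition but stays within the usual scatter. For compound 3 the estimate is 100000 nM, expected to fall between 50000 nM and 200000 nM.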

Compound 3, half-maximal inhibitory concentration: > 100000 nM
Compound 3 was reported as a limit; the forecaster's own chance of this, stated with the estimate: 50%; the middle value sits exactly at the limit.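

In this assay compound 3 reads > 100000 nM, which is a limit of the assay and not a number. Methoxy in place of trifluoromethyl at this position, meta to a large group, gives an at least 1.3-fold higher number from compound 1 to compound 3 (0.11 log units; that floor lies within the scatter), so only a floor for this change is known, not its true size. The reading of compound 3 joins a ceiling that already held one earlier compound: the limit of > 100000 nM in this assay, at which 2 of the 3 values shown sit.

From the compounds shown here alone, how far compound 3 really lies from compound 1 stays open. So does whether an amine or a carboxylic acid at this position would give a lower number than compound 1.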